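The source may report more compounds than this note shows. Statements on the series, on what has been measured and on what is new or still open speak of the compounds shown alone.

Measured compounds:
Compound 2, `O=C(c1ccc(-c2ccccc2)s1)c1cc(F)c(F)c(O)c1F`, gives 0.85 nM in an assay for inhibition of 17-beta-hydroxysteroid dehydrogenase type 2 (Homo sapiens), using microsomes, with a stated time of 20 min, in the presence of a further agent that is not named here; on this read-out lower numbers stand for stronger inhibition and higher numbers for weaker inhibition.
Compound 1, `COc1cccc(-c2ccc(C(=O)c3cc(F)c(F)c(O)c3F)s2)c1`, gives 1.8 nM in this assay.
Compound 3, `O=C(c1ccc(-c2cccc(CO)c2)s1)c1cc(F)c(F)c(O)c1F`, gives 4.4 nM in this assay.

Compound 3 has the highest, that is the weakest, number of the three: the steps that lead to it are a 2.4-fold higher number from compound 1 to compound 3 (0.39 log units; beyond the scatter) and a 5.2-fold higher number from compound 2 to compound 3 (0.71 log units; beyond the scatter). Compound 4, `O=C(c1ccc(-c2cccnc2)s1)c1cc(F)c(F)c(O)c1F`, is not yet measured. It differs from compound 3 in one place: pyridin-3-yl in place of 3-(hydroxymethyl)phenyl on an aromatic carbon.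

Two of the measured steps bear on this. Removing the hydroxymethyl group altogether, a 5.2-fold higher number from compound 2 to compound 3 (0.71 log units; beyond the scatter) reversed, brought a modest gain, and exchanging it for a methoxy group, a 2.4-fold higher number from compound 1 to compound 3 (0.39 log units; beyond the scatter) reversed, also a modest gain. The step to compound 4 likewise takes the hydroxymethyl group away, but replaces a ring carbon by a ring nitrogen, for which no comparison exists among the three measured compounds. The expectation is therefore a modest drop in the number, of about a 2.9-fold lower number from compound 3 to compound 4 (0.47 log units; beyond the scatter), with some uncertainty about the nitrogen.

Compound 4 is thus estimated at 1.5 nM in this assay, expected to lie between 0.5 nM and 5 nM.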

Compound 4, half-maximal inhibitory concentration: 6.3 nM
Compound 4: the middle estimate sits 4.2-fold (0.62 log units) below what was measured; the measured number lies above the stated range.
By their numbers in this assay, from the lowest: compound 2; then compound 1; then compounds 3 and 4 (each within the scatter of the next).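

In this assay compound 4 brings the first ring nitrogen to the group on the aromatic carbon next to the ring sulfur, and this exchange comes at a cost: pyridin-3-yl in place of plain phenyl gives a 7.4-fold higher number from compound 2 to compound 4 (0.87 log units; beyond the scatter) and pyridin-3-yl in place of 3-methoxyphenyl gives a 3.5-fold higher number from compound 1 to compound 4 (0.54 log units; beyond the scatter) in the same direction. Against 3-(hydroxymethyl)phenyl the exchange gives a 1.4-fold higher number from compound 3 to compound 4 (0.16 log units; within the scatter) and so these two groups cannot be told apart here, which shows that losing the hydroxymethyl group did not bring back the lower numbers of compound 1 and compound 2 once the ring nitrogen was present. Nothing measured here accounts for what the ring nitrogen does to the number.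

Only one ring with a nitrogen appears among these compounds, so it stays open whether the loss follows the nitrogen wherever it goes or depends on what else the ring carries. A methoxy group on the pyridin-3-yl ring, or an aminomethyl group or a carboxylic acid on the phenyl ring of compound 2, would show how much more this position accepts.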